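Dichlorophenyl in Place of Phenyl on a Thiazinone Core

A few compounds are considered here, and "the series" means these few. Any claim that something is new, unique, unknown or untested is made for them only; others in the source may bear on it.

Of the compounds shown here, three have been measured in an in vitro assay on cells for inhibition of Amine oxidase [flavin-containing] B (Homo sapiens), read by fluorescence and Amplex Red, with stated times of 30 min and 45 min; a higher number here means a weaker inhibitor, a lower number a stronger inhibitor. Compound 1 `O=C(CCc1ccccc1)Nc1nc2ccccc2c(=O)s1` gives 17.6 nM, the lowest number of the three. Compound 3 `O=C(CCCc1ccccc1)Nc1nc2sccc2c(=O)s1` gives 69.7 nM, a gap beyond the scatter, and compound 2 `COc1cccc(/C=C/C(=O)Nc2nc3ccccc3c(=O)s2)c1` gives 470 nM, the furthest from compound 1. Compound 4 `O=C(CCc1ccc(Cl)c(Cl)c1)Nc1nc2ccccc2c(=O)s1` keeps the core of compound 1 and differs in one place only: 3,4-dichlorophenyl in place of phenyl on a saturated chain carbon, two bonds along the chain from a carbonyl carbon. For the measured compounds named here, no measured pair shows this kind of exchange, so nothing here tells how much two chlorines on that ring matter. A modest step is expected, most likely within the scatter or a slight gain in potency. Compound 4 is therefore estimated at 12 nM, with a range from 4 nM to 40 nM, meaning an expected step of a 1.5-fold lower number from compound 1 to compound 4 (0.17 log units; within the scatter).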

Compound 4, half-maximal inhibitory concentration: > 10000 nM
Compound 4 ended at the assay's limit (the forecaster's own chance of this, stated with the estimate: 2%); middle value at least 830-fold (2.92 log units) away from the limit.
By their numbers in this assay, from the lowest: compound 1; then compound 3; then compound 2. At a limit, above all of these: compound 4.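

Placing two chlorines on the phenyl ring gives an at least 560-fold higher number from compound 1 to compound 4 (2.75 log units; beyond the scatter), so this ring, which no earlier pair varied on its own, is far less forgiving of change than the first three compounds could show. Compound 4 stands at a limit of the assay, not at a measured number: the limit of > 10000 nM in this assay, at which 1 of the 4 values shown sits.

The compounds shown do not tell whether one chlorine alone would cost as much as two. As far as these compounds go, how a single fluorine or a methyl group on this phenyl ring would fare also remains open.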